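The compounds below may be only part of what the source reports. "The series", "measured", "known", "first", "only" and "open" are said of these compounds alone.

Working notes on the series. Compound 2 `CS/C(=N\C(=O)c1cc2ccccc2s1)NC(=O)c1cc2ccccc2s1` gives 98600 nM in a functional assay on K562 cells (Homo sapiens) for cytotoxicity, read by MTT assay, with a stated time of 72 h; on this read-out higher numbers stand for lower toxicity in this test and lower numbers for higher toxicity in this test. Among the three compounds measured so far compound 2 holds the highest number, though both other numbers sit within the scatter of it: compound 1 `C[Se]/C(=N\C(=O)c1cc2ccccc2s1)NC(=O)c1cc2ccccc2s1` gives 89600 nM in this assay, and compound 3 `O=C(/N=C(/NC(=O)c1csc([N+](=O)[O-])c1)[Se]Cc1ccccc1)c1csc([N+](=O)[O-])c1` gives 88200 nM. Compound 4 `O=C(/N=C(/NC(=O)c1cc2ccccc2s1)[Se]Cc1ccccc1)c1cc2ccccc2s1` has not yet been measured. Relative to compound 2 it carries a group of 8 heavy atoms (7 carbon, 1 selenium; one six-membered aromatic ring of carbon only) in place of a group of 2 heavy atoms (1 carbon, 1 sulfur; no ring), on a carbon with a double bond to nitrogen. Within the data shown here, only one measured step touches the same place: a 1.1-fold higher number from compound 1 to compound 2 (0.04 log units; within the scatter), where selenium gave way to sulfur on the carbon with a double bond to nitrogen without any shift beyond the scatter. Among the measured compounds shown here, no measured step tests the entry of the benzyl group on the shared core of compound 2. Compound 3 does carry the same selenium-linked benzyl group, but on a different core, so for compound 3 and compound 2 only the two values themselves can be compared, and they lie within the scatter of one another. The expectation for compound 4 is therefore a step of a 1.1-fold lower number from compound 2 to compound 4 (0.04 log units; within the scatter), nothing beyond the scatter. Compound 4 is estimated at 90000 nM, with a range from 45000 nM to 180000 nM.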

Compound 4, concentration lethal to 50% of the cells: 70600 nM
For compound 4 the middle estimate is 1.3-fold (0.11 log units) above the measured one, and the stated range covers the measured number.
By their numbers in this assay, from the lowest: compounds 4, 3, 1 and 2 (each within the scatter of the next).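

In this assay the carbon with a double bond to nitrogen, whose other neighbours are the two amide-type nitrogens, now has a test of group size on the shared core and not only of an exchange of selenium for sulfur: the selenium-linked group of 8 heavy atoms in place of methylsulfanyl gives a 1.4-fold lower number from compound 2 to compound 4 (0.15 log units; within the scatter) and so does not move the read-out beyond the usual variation. Phenyl in place of hydrogen on the saturated chain carbon bound to selenium, the narrower one-place change, gives a 1.3-fold lower number from compound 1 to compound 4 (0.10 log units; within the scatter) and likewise stays within the scatter, so both routes to compound 4 agree that this position takes the added aromatic ring without a resolved shift in this test. Nothing measured here offers an explanation for this flat response at the position.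

The compounds shown leave open whether the exchange of selenium for sulfur stays equally silent when the chain carries phenyl, as it does with the methyl-bearing pair. They also leave open whether a different group at this place, such as an amine, a carboxylic acid or a longer chain on the selenium, would produce a step beyond the scatter on the shared core.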